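From methyl to bromo on compound 3

The source may report more compounds than this note shows. Statements on the series, on what has been measured and on what is new or still open speak of the compounds shown alone.

Among the compounds with values here, in a functional assay on HeLa cells (Homo sapiens) for antiproliferative activity, read by MTT assay, with a stated time of 72 h (a higher number here means a weaker inhibitor, a lower number a stronger inhibitor), compound 3 `COc1cc(-c2nccn2-c2ccc(C)cc2)cc(OC)c1OC` gives 700 nM as the only actual number so far. Compound 1 `CCCn1ccnc1-c1cc(OC)c(OC)c(OC)c1` shows > 100000 nM which is a limit. Compound 2 `CCCCn1ccnc1-c1cc(OC)c(OC)c(OC)c1` shows > 100000 nM which is also a limit. Compound 4 `COc1cc(-c2nccn2-c2ccc(Br)cc2)cc(OC)c1OC` carries bromo in place of methyl on an aromatic carbon, para to a large group bromo in place of methyl on an aromatic carbon and is still unmeasured. Within the data shown here, two steps bear on it: an at least 140-fold lower number from compound 1 to compound 3 (2.15 log units; beyond the scatter) and an at least 140-fold lower number from compound 2 to compound 3 (2.15 log units; beyond the scatter) are both large, yet each swaps a whole chain for 4-methylphenyl. Among the measured compounds shown here, no measured step alters the group on that ring, so a 1.2-fold lower number from compound 3 to compound 4 (0.07 log units; within the scatter) is expected to stay within the scatter. Compound 4 is estimated at 600 nM with a likely range from 120 nM to 3000 nM in this assay once measured.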

Compound 4, half-maximal inhibitory concentration: 3300 nM
Compound 4: middle estimate off by 5.5-fold (0.74 log units), on the low side; measured number above the stated range.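

In this assay, bromo in place of methyl gives a 4.7-fold higher number from compound 3 to compound 4 (0.67 log units; beyond the scatter), so the group on this ring matters as well as the ring itself. The 4-bromophenyl compound still keeps a large advantage over both chains, with an at least 30-fold lower number from compound 2 to compound 4 (1.48 log units; beyond the scatter) and an at least 30-fold lower number from compound 1 to compound 4 (1.48 log units; beyond the scatter). Both of these steps start from a limit, not a number: the limit of > 100000 nM in this assay, at which 2 of the 4 values shown sit.

With only methyl and bromo compared at this place, no trend across groups can be drawn. From the compounds shown here alone, whether fluoro or an amine there would land nearer compound 3 or compound 4 remains open.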